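Fluoro for Methoxy on the Pendant Phenyl Ring

The source may hold more compounds than are shown below. What is called first, only, known or untested is meant among the compounds shown, and "the series" means these compounds.

Within the data shown here, compound 2 `COc1ccccc1-c1cn2ccnc2c(-c2ccc3ncn(C4CCCCC4)c3c2)n1` stands lowest of the two numbers so far in a functional assay on T47D cells (Homo sapiens) for inhibition, read by sulforhodamine B assay, with a stated time of 48 h, tested at 10 uM (on this read-out higher numbers stand for more inhibition at the one concentration tested (going by the name of the read-out) and lower numbers for less inhibition), where compound 2 gives 36.6%. Its nearest neighbour is compound 1 `O=Cc1ccc(-c2cn3ccnc3c(-c3ccc4ncn(C5CCCCC5)c4c3)n2)cc1`, which gives 98% in this assay. Among the measured compounds shown here, the one measured step, a number 61.4 percentage points lower from compound 1 to compound 2 (beyond the scatter), came with 2-methoxyphenyl in place of 4-formylphenyl on an aromatic carbon. Compound 3 `Fc1ccccc1-c1cn2ccnc2c(-c2ccc3ncn(C4CCCCC4)c3c2)n1` differs from compound 2 by fluoro in place of methoxy on an aromatic carbon. For the measured compounds named here, no measured step swaps fluoro for methoxy, and the single step on record changes both the group and its position on the ring, so it bears only loosely on this change. The account therefore expects a modest step from compound 2 to compound 3, a number 1.4 percentage points higher from compound 2 to compound 3 (within the scatter), with direction uncertain. Compound 3 is estimated at 38% in this assay, with a range from 12% to 68%.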

Compound 3, a percentage reported as inhibition, at one concentration (the size of the read-out at that concentration, not a potency): 77.2%
Beside the measured number, compound 3's estimate is 39.2 percentage points below it, outside the stated range (above it).
By their numbers in this assay, from the lowest: compound 2; then compound 3; then compound 1.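

In this assay, the group ortho to a large group on the pendant ring proves decisive on its own: with the place held fixed, the change from methoxy to fluoro gives a number 40.6 percentage points higher from compound 2 to compound 3 (beyond the scatter). The earlier step changed both group and place at once, so it could not show this; the 2-fluorophenyl ring now recovers much of the read-out, yet a number 20.8 percentage points lower from compound 1 to compound 3 (beyond the scatter), leaving the 4-formylphenyl compound ahead. Nothing available explains why fluoro and methoxy differ so sharply here.

On these data alone, it remains open how other groups at this same place, such as chloro, hydroxyl or an amine, would compare with fluoro and methoxy. Also open, as far as these compounds go, is whether fluoro or methoxy would behave the same way at the place held by the formyl group in compound 1.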